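This account rests on a few compounds, and the source may have more. Where it says the series, first, only, none or still open, it means among the compounds named here.

Compound 1 `Cc1cccc(C)c1NC(=O)/C=C/C(=O)N1C/C(=C\c2ccccc2)C(=O)/C(=C/c2ccccc2)C1` carries a 2,6-dimethylphenyl group on an amide-type nitrogen, and in a functional assay on CCRF-CEM cells (Homo sapiens) for cytotoxicity (on this read-out higher numbers stand for weaker inhibition and lower numbers for stronger inhibition), compound 1 gives 7400 nM. Compound 2 `COc1ccc(NC(=O)/C=C/C(=O)N2C/C(=C\c3ccccc3)C(=O)/C(=C/c3ccccc3)C2)cc1` bears a 4-methoxyphenyl group at the same place instead, and in this assay compound 2 gives 510 nM. That single exchange produced a 15-fold lower number from compound 1 to compound 2 (1.16 log units; beyond the scatter). Among the two compounds measured so far, compound 2 therefore holds the lowest number, with compound 1 the nearest at a higher one.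

Compound 3 `O=C(/C=C/C(=O)N1C/C(=C\c2ccccc2)C(=O)/C(=C/c2ccccc2)C1)Nc1ccc(Cl)cc1` has not yet been measured. It keeps everything of compound 2 except one change: chloro in place of methoxy on an aromatic carbon. Going by the values given here, only one measured step speaks to this change, the one from compound 1 to compound 2, which exchanged the entire aryl group and moved the number a long way. Among the compounds with values here, the present exchange is more modest, as it replaces one small group para to a large group with another, and the numbers so far say nothing about how a chloro compares with a methoxy. The expected step in this assay is a 1.4-fold higher number from compound 2 to compound 3 (0.14 log units; within the scatter). Compound 3 is thus estimated to give 700 nM, with a range from 250 nM to 2500 nM.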

Compound 3, half-maximal inhibitory concentration: 840 nM
Compound 3: the middle estimate sits 1.2-fold (0.08 log units) below what was measured; measured number inside the range.
By their numbers in this assay, from the lowest: compounds 2 and 3 (each within the scatter of the next); then compound 1.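

In this assay, the step from methoxy to chloro on the aromatic carbon para to a large group is small (a 1.6-fold higher number from compound 2 to compound 3 (0.22 log units; within the scatter)), so these two compounds cannot be told apart, even though the groups differ in their atoms and only methoxy counts a hydrogen-bond acceptor. The large step seen earlier now has a second instance, since exchanging the 2,6-dimethylphenyl group for 4-chlorophenyl also moves the number well past the usual scatter (an 8.8-fold lower number from compound 1 to compound 3 (0.94 log units; beyond the scatter)), and among these three compounds both 4-substituted phenyl compounds sit apart from compound 1, with none going against this. Nothing available explains why methoxy and chloro read alike here or why compound 1 stands apart.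

On these data alone, whether this place would also tolerate an amine, a carboxylic acid or a longer chain such as butoxy remains open, as two groups cannot show how wide the tolerance is. Also open, as far as these compounds go, is what separates compound 1 from the others, the two methyl groups or their place on the ring, and a 4-methylphenyl group would be needed to pull those two apart.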